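Swapping trifluoromethyl for methoxymethyl on a second core

The source may hold more compounds than are shown below. What is called first, only, known or untested is meant among the compounds shown, and "the series" means these compounds.

Two measured compounds share a core and a 3-(trifluoromethyl)phenyl side chain: compound 1 `O=C(O)CCCSCCN1C(=O)OC[C@@H]1/C=C/[C@@H](O)Cc1cccc(C(F)(F)F)c1` and compound 2 `O=C(O)CCCSCCN1C(=O)SC[C@@H]1/C=C/[C@@H](O)Cc1cccc(C(F)(F)F)c1`. In an assay on CHO cells for displacement of a labelled ligand from prostaglandin E2 receptor EP3 subtype (Mus musculus), read by scintillation counting, with a stated time of 60 min (on this read-out higher numbers stand for weaker inhibition and lower numbers for stronger inhibition), compound 1 gives 1600 nM, and compound 2 gives 280 nM, the lower of the two numbers. How the two cores differ is not broken down here.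

Compound 3 `COCc1cccc(C[C@H](O)/C=C/[C@H]2COC(=O)N2CCSCCCC(=O)O)c1` carries the change methoxymethyl in place of trifluoromethyl on an aromatic carbon on the core of compound 1. In this assay compound 3 reaches only a limit, > 10000 nM, and that is all this value says. The change thus produced an at least 6.2-fold higher number from compound 1 to compound 3 (0.79 log units; beyond the scatter), a step whose true size is open because the limit of > 10000 nM in this assay, at which 1 of the 3 values shown sits, caps what can be seen.

Compound 4 `COCc1cccc(C[C@H](O)/C=C/[C@H]2CSC(=O)N2CCSCCCC(=O)O)c1` is the same kind of change, (methoxymethyl in place of trifluoromethyl on an aromatic carbon), made on the core of compound 2. It has not yet been measured in this assay. Given the measured step from compound 1 to compound 3, a weakening of similar size is expected, namely an 8.9-fold higher number from compound 2 to compound 4 (0.95 log units; beyond the scatter). Compound 4 is therefore estimated at about 2500 nM, with a likely range from 900 nM to 10000 nM.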

Compound 4, inhibition constant: > 10000 nM
Compound 4 was reported as a limit; the forecaster's own chance of this, stated with the estimate: 25%; at least 4.0-fold (0.60 log units) between middle value and limit.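

In this assay compound 4 reaches only > 10000 nM, which is a limit of the assay and not a number. On the core of compound 2, methoxymethyl in place of trifluoromethyl therefore gives an at least 35-fold higher number from compound 2 to compound 4 (1.55 log units; beyond the scatter), a large step. The change weakens inhibition on both cores, so its direction carries across these two cases, but the data do not show that its size carries across as well: the same change on two cores in this assay, an at least 6.2-fold higher number (0.79 log units; beyond the scatter) from compound 1 to compound 3 and an at least 35-fold higher number (1.55 log units; beyond the scatter) from compound 2 to compound 4; the limit leaves it open whether they differ

The compounds shown leave open how the read-out responds to other groups at this place on the aromatic ring, since only trifluoromethyl and methoxymethyl appear there, and a nitrile, a chlorine or an ethyl group is not among them. Also open, going by these compounds, are the true size of the step on each core and whether a hydroxymethyl group or an ether with a longer chain would give a measurable number on the core of compound 2.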